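Ethynyl for Thiophen-2-yl on Two Related Nucleoside Cores

The source may report more compounds than this note shows. Statements on the series, on what has been measured and on what is new or still open speak of the compounds shown alone.

Of the compounds shown here, three have been tested in a functional assay on HCT-116 cells (Homo sapiens), read by MTT assay, with a stated time of 72 h; a lower number here means a stronger inhibitor, a higher number a weaker inhibitor: compound 3 `Cc1ncnc2c1c(-c1cccs1)cn2[C@@H]1O[C@H](CO)[C@@H](O)[C@H]1O`, compound 1 `C#Cc1cn([C@@H]2O[C@H](CO)[C@@H](O)[C@H]2O)c2ncnc(C)c12` and compound 2 `COc1nc(N)nc2c1c(-c1cccs1)cn2[C@@H]1O[C@H](CO)[C@@H](O)[C@H]1O`. In this assay compound 3 gives > 20000 nM, which is a limit of the assay. In this assay compound 1 gives > 20000 nM, also a limit. In this assay compound 2 gives > 20000 nM, again a limit, so (the limit of > 20000 nM in this assay, at which 3 of the 3 values shown sit). The change from compound 3 to compound 1 is ethynyl in place of thiophen-2-yl on an aromatic carbon, and the resulting step that the two limits leave unreadable from compound 3 to compound 1 cannot be sized. The difference between the cores of compound 2 and compound 3 is not broken down here. The unmeasured compound 4 `C#Cc1cn([C@@H]2O[C@H](CO)[C@@H](O)[C@H]2O)c2nc(N)nc(OC)c12` carries the same change on the core of compound 2: ethynyl in place of thiophen-2-yl on an aromatic carbon. Because compound 2 already sits at > 20000 nM, the step from compound 2 to compound 4 is expected to be a step that the limit leaves unreadable from compound 2 to compound 4, again unreadable. Compound 4 is estimated at 30000 nM in this assay, with a range of 15000 nM to 100000 nM.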

Compound 4, half-maximal inhibitory concentration: > 20000 nM
Compound 4 gave a limit, no number; the forecaster's own chance of this, stated with the estimate: 90%; the middle value does not contradict the limit.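

No new step can be read between compound 2 and compound 4, as the result for compound 4 is again a limit and not a number: the limit of > 20000 nM in this assay, at which 4 of the 4 values shown sit.

The compounds shown leave open how ethynyl and thiophen-2-yl compare in this assay on either core.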